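Flipping the Double Bond: From Compound 3 to Compound 4

The compounds below may be only part of what the source reports. "The series", "measured", "known", "first", "only" and "open" are said of these compounds alone.

Measured compounds:
- compound 1 `O=C1Nc2ccc(Cl)cc2/C1=C/c1cccc(OCc2cn(Cc3ccccc3)nn2)c1`: compound 1 gives "not determined" (no result reported) in a functional assay on MDA-MB-231 cells (Homo sapiens) for inhibition, read by MTT assay, with a stated time of 48 h; a higher number here means a weaker inhibitor, a lower number a stronger inhibitor
- compound 2 `CC(=O)c1ccc2c(c1)/C(=C/c1cccc(OCc3cn(Cc4ccccc4)nn3)c1)C(=O)N2`: compound 2 gives > 50000 nM in this assay, which is a limit rather than a number
- compound 3 `COc1ccc(Cc2ccc3c(c2)/C(=C\c2cccc(OCc4cn(Cc5ccccc5)nn4)c2)C(=O)N3)cc1`: compound 3 gives > 50000 nM in this assay, again a limit rather than a number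

Compound 3 therefore stands at the edge of what this assay can report: of the three values shown, two sit at the limit of > 50000 nM in this assay, at which 2 of the 3 values shown sit, and the third has no number at all. Going by the values given here, no pair of measured compounds differs in just one place, so no measured step is available to lean on.

Compound 4 `COc1ccc(Cc2ccc3c(c2)/C(=C/c2cccc(OCc4cn(Cc5ccccc5)nn4)c2)C(=O)N3)cc1` is the unmeasured partner of compound 3. The change is small on paper: the two compounds have the same atoms and bonds and differ only in configuration as drawn: 1 of 1 stereo elements differ; a double bond is drawn E in compound 3 and Z in compound 4. Since neither compound 3 nor any other measured compound gives a readable number, there is no direct evidence for how much this flip matters, and the expected step of an at least 1.1-fold lower number from compound 3 to compound 4 (0.04 log units; that floor lies within the scatter) is taken as small, with a strong chance that compound 4 is again reported only as a limit. Compound 4 is therefore expected to give about 45000 nM in this assay, within a range from 8000 nM to 150000 nM.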

Compound 4, half-maximal inhibitory concentration: 20400 nM
Estimate against measurement, compound 4: 2.2-fold (0.34 log units) above, within the range that was stated.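

In this assay compound 4 gives 20400 nM, the first readable number among the compounds shown. Compound 3 gives > 50000 nM, which is a limit and not a number. With 4-methoxybenzyl in place of acetyl on an aromatic carbon, the data show an at least 2.4-fold lower number from compound 2 to compound 4 (0.38 log units; beyond the scatter), while the change in the double bond alone gives an at least 2.4-fold lower number from compound 3 to compound 4 (0.38 log units; beyond the scatter), and that second step can be laid on the double bond because of: the fact that compounds 3 and 4 differ only in the configuration as drawn

On these data alone, both steps start from a limit, so their true size stays open. Also open, as far as these compounds go, is how an amine or a carboxylic acid in place of the 4-methoxybenzyl would read, and whether the same flip of the double bond would change the number with the acetyl group in place.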